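Adding a methyl to compound 3: working notes

The compounds below may be only part of what the source reports. "The series", "measured", "known", "first", "only" and "open" are said of these compounds alone.

Measured in a functional assay on U-373MG ATCC cells (Homo sapiens) for inhibition, read by colorimetric assay and MTT assay, with a stated time of 72 h; a higher number here means a weaker inhibitor, a lower number a stronger inhibitor:
- compound 1 `Cn1c2cnc1OCCCCCCCCOc1ccc(F)cc1-2`: 73000 nM
- compound 2 `Cn1c2cnc1OCCCCCCCCCCOc1cc3ccccc3cc1-2`: 29000 nM
- compound 3 `C=CCCCCOc1ccccc1-c1cnc(OCCC=C)n1C`: 33000 nM

In this assay, compound 3 at 33000 nM has the second highest of the three numbers, but it lies within the scatter of compound 2 at 29000 nM. Compound 1 at 73000 nM has a higher number than compound 3, and that gap lies beyond the scatter.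

The next entry is compound 4 `C=CCCCCOc1ccc(C)cc1-c1cnc(OCCC=C)n1C`, which differs from compound 3 in one place: methyl in place of hydrogen on an aromatic carbon. This is methyl in place of hydrogen on an aromatic carbon, para to a (hex-5-en-1-yl)oxy group.

Within the data shown here, no pair of measured compounds differs in only one place, so the series offers no direct measure of this change. With so small a change, no step beyond the scatter is expected in this assay, although a slight lean towards a lower number is allowed for. The expectation is anchored on compound 3 at 33000 nM.

The expected step is a 1.2-fold lower number from compound 3 to compound 4 (0.07 log units; within the scatter), which stays within the scatter. For compound 4 the estimated value is 28000 nM, with an expected range from 13000 nM to 60000 nM.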

Compound 4, half-maximal inhibitory concentration: 33000 nM
Beside the measured number, compound 4's estimate is 1.2-fold (0.07 log units) below it, and the stated range covers the measured number.
By their numbers in this assay, from the lowest: compounds 2, 3 and 4 (each within the scatter of the next); then compound 1.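

In this assay, among these compounds, methyl in place of hydrogen on an aromatic carbon gives no change at the digits printed from compound 3 to compound 4 (within the scatter), and this is the first direct reading of a single change, since the earlier compounds offered no pair differing in one place. At this position, para to a (hex-5-en-1-yl)oxy group and meta to a large group, adding one carbon as a methyl therefore leaves the number where it stood, so this position accepts that small group without a step beyond the scatter. Nothing available bears on why the step is flat, and the pair gives a size of effect with no explanation attached.

As far as these compounds go, this single pair speaks only for methyl, so it remains open whether an amine, a carboxylic acid or a longer chain at the same position would move the number beyond the scatter. From the compounds shown here alone, it also remains open whether methyl at this position would read the same on the core of compound 1 or compound 2, as the present step comes only from the open-chain pair.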